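The source may report more compounds than this note shows. Statements on the series, on what has been measured and on what is new or still open speak of the compounds shown alone.

Going by the values given here, compound 1 `O=c1c(-c2ccc(O)cc2)coc2cc(OCCOCCOCCO)ccc12` holds the only numerical value in this set: in an assay (Cricetulus griseus) for inhibition of aldehyde dehydrogenase, mitochondrial (Homo sapiens) (a lower number here means a stronger inhibitor, a higher number a weaker inhibitor), compound 1 gives 40 nM. The second measured compound, compound 2 `O=C(O)COc1ccc(-c2coc3cc(OCC(=O)O)ccc3c2=O)cc1`, reaches only a limit of this assay, and compound 2 is recorded as >> 9000 nM. Among the compounds with values here, no step between two measured compounds can be read from these data; what stands beside the value of compound 1 is the limit of >> 9000 nM in this assay, at which 1 of the 2 values shown sits.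

The account turns to compound 3 `O=C(O)CCCCOc1ccc2c(=O)c(-c3ccc(O)cc3)coc2c1`, which has not been measured in this assay. Its difference from compound 1 is 2-carboxyethyl in place of 2-(2-hydroxyethoxy)ethoxy on a saturated chain carbon, two bonds along the chain from an oxygen on an aromatic ring. For this change the step from compound 1 to compound 3 in this assay is expected to go towards weaker inhibition, beyond the usual scatter but of moderate size. Compound 3 is therefore estimated at 300 nM, with a range from 60 nM to 2000 nM. That estimate corresponds to an expected step of a 7.5-fold higher number from compound 1 to compound 3 (0.88 log units; beyond the scatter).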

Compound 3, half-maximal inhibitory concentration: 100 nM
Compound 3: middle estimate off by 3.0-fold (0.48 log units), on the high side; the range from low to high includes it.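

In this assay, 2-carboxyethyl in place of 2-(2-hydroxyethoxy)ethoxy on a saturated chain carbon, two bonds along the chain from an oxygen on an aromatic ring, gives a 2.5-fold higher number from compound 1 to compound 3 (0.40 log units; beyond the scatter), a modest loss. This position therefore accepts a chain ending in a carboxylic acid instead of one ending in a hydroxyl with ether oxygens, and compound 3 still gives a numerical value of 100 nM. Nothing measured here gives a cause for this step.

The compounds shown leave open whether the step follows from the carboxylic acid or from the loss of the ether oxygens, since the two chains differ in both. They also leave open how an amine, a methyl ester or a longer chain ending in a carboxylic acid would read at this position.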